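Naphthyl for bromophenyl on a quinoline hydrazone

The compounds below may be only part of what the source reports. "The series", "measured", "known", "first", "only" and "open" are said of these compounds alone.

Of the compounds shown here, two have been measured in an ADME assay on HUVEC cells (Homo sapiens) for cytotoxicity, read by MTT assay, with a stated time of 48 h; a higher number here means a weaker inhibitor, a lower number a stronger inhibitor. Compound 1 `Cc1ccc2nc(Cl)c(/C=N/n3cc(-c4ccccc4)nc3N)cc2c1` gives 41500 nM, while compound 2 `Cc1ccc2nc(Cl)c(/C=N/n3cc(-c4ccc(Br)cc4)nc3N)cc2c1` gives 13400 nM. Compound 2 thus holds the lowest of the two numbers, and the step of a 3.1-fold lower number from compound 1 to compound 2 (0.49 log units; beyond the scatter) is the only one seen so far. Compound 3 `Cc1ccc2nc(Cl)c(/C=N/n3cc(-c4ccc5ccccc5c4)nc3N)cc2c1` is not yet measured; it differs from compound 2 by naphthalen-2-yl in place of 4-bromophenyl on an aromatic carbon. Going by the values given here, no measured pair shows this exact exchange, so the only guidance is the step from compound 1 to compound 2, where a change at the same aryl group moved this assay beyond the scatter toward a lower number. On that basis the account expects a modest further move downward, a 1.7-fold lower number from compound 2 to compound 3 (0.22 log units; within the scatter), though a result within the scatter of compound 2 would not surprise. The estimate for compound 3 in this assay is 8000 nM, with a range from 3000 nM to 25000 nM.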

Compound 3, half-maximal inhibitory concentration: 11400 nM
The estimate for compound 3 lay 1.4-fold (0.15 log units) below the measured number; the measured number falls inside the stated range.
By their numbers in this assay, from the lowest: compounds 3 and 2 (each within the scatter of the next); then compound 1.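

In this assay, naphthalen-2-yl in place of 4-bromophenyl gives a 1.2-fold lower number from compound 2 to compound 3 (0.07 log units; within the scatter), so this position does not separate the two groups, though one carries bromine and the other has two aromatic rings of carbon only. Measured against the phenyl group, naphthalen-2-yl gives a 3.6-fold lower number from compound 1 to compound 3 (0.56 log units; beyond the scatter), which shows that among these three compounds the step away from phenyl does not depend on bromine, since an all-carbon group goes with a similar number. No measurement at hand explains these numbers.

On these data alone, whether this aromatic carbon would give a similar number with a non-aromatic group, such as a morpholine or a carboxylic acid, remains open. Also open, as far as these compounds go, is how this assay would respond to an amine in place of the chloro group on the shared core.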